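Halogen swap on the fused core: fluoro to bromo

A few compounds are considered here, and "the series" means these few. Any claim that something is new, unique, unknown or untested is made for them only; others in the source may bear on it.

Measured so far:
compound 1 `CCN(Cc1ccc(C)cc1)c1cc(C)nc2c(-c3cnc(N(C)C)cc3C)c(C)nn12` — 2.3 nM
compound 2 `CCCN(CCC)c1c(F)c(C)nc2c(-c3cnc(N(C)C)cc3C)c(C)nn12` — 5.6 nM

In an assay on CHO cells for binding affinity to corticotropin-releasing factor receptor 1 (Homo sapiens) (on this read-out lower numbers stand for stronger inhibition and higher numbers for weaker inhibition), compound 1 gives 2.3 nM and compound 2 gives 5.6 nM; compound 2 holds the higher of the two numbers, a gap beyond the scatter. Compound 3 `CCCN(CCC)c1c(Br)c(C)nc2c(-c3cnc(N(C)C)cc3C)c(C)nn12` differs from compound 2 only by bromo in place of fluoro on an aromatic carbon. For the measured compounds named here, no pair of measured compounds shows the effect of this exchange, so the direction is uncertain. A step of modest size is expected, a 1.2-fold lower number from compound 2 to compound 3 (0.09 log units; within the scatter), with neither direction clearly favoured. Compound 3 is estimated at 4.5 nM, within 1.5 nM to 14 nM.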

Compound 3, inhibition constant: 240 nM
For compound 3 the middle estimate is 53-fold (1.73 log units) below the measured one, outside the stated range (above it).
By their numbers in this assay, from the lowest: compound 1; then compound 2; then compound 3.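

In this assay, the halogen on this aromatic carbon, ortho to the dipropylamino group and to the methyl group, is not a neutral choice: bromo in place of fluoro gives a 43-fold higher number from compound 2 to compound 3 (1.63 log units; beyond the scatter) and this step is large. With the dipropylamino group held constant, affinity therefore depends strongly on which halogen occupies this position. Nothing available explains the size of this step.

Open, from the compounds shown here alone, is whether chloro or methoxy on this carbon would read closer to compound 2 or compound 3. Also open, going by these compounds, is whether the same exchange carries a comparable penalty alongside the amine of compound 1.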